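A few compounds are considered here, and "the series" means these few. Any claim that something is new, unique, unknown or untested is made for them only; others in the source may bear on it.

Compound 1 `CCCCN(C)c1nc(C(C)(C)C)ccc1CNC(=O)C(C)c1ccc(NS(C)(=O)=O)c(F)c1` gives 1.2 nM in an assay on cells for antagonist activity at transient receptor potential cation channel subfamily V member 1 (Homo sapiens), read by FLIPR and calcium flux, with a stated time of 6 min; a higher number here means a weaker inhibitor, a lower number a stronger inhibitor. Compound 2 `CC(C(=O)NCc1ccc(C(C)(C)C)nc1OCc1ccccc1)c1ccc(NS(C)(=O)=O)c(F)c1` gives 4.4 nM. Compound 3 `CC(C(=O)NCc1ccc(C(C)(C)C)cc1N1CCN(c2ccccc2)CC1)c1ccc(NS(C)(=O)=O)c(F)c1` gives 0.8 nM.

Compound 3 and compound 1 cannot be told apart by their numbers, as the gap between them is within the usual scatter; compound 2 stands clearly higher than either. Compound 4 `CCCCSc1cc(C(C)(C)C)ccc1CNC(=O)C(C)c1ccc(NS(C)(=O)=O)c(F)c1` has not yet been measured. It differs from compound 3 in one place: butylsulfanyl in place of 4-phenylpiperazin-1-yl on an aromatic carbon. Among the measured compounds shown here, the only measured step that bears on this is the exchange at the same kind of position between compound 1 and compound 2, where benzyloxy replaced butyl(methyl)amino and gave a 3.7-fold higher number from compound 1 to compound 2 (0.56 log units; beyond the scatter). That step shows that swapping the group on this aromatic carbon shifts the number modestly rather than drastically. Since a large ring-bearing group leaves and a short chain enters, a modest rise in this assay is the likelier outcome. Compound 4 is therefore expected to give about 3 nM, within a range from 1 nM to 10 nM. This corresponds to an expected 3.8-fold higher number from compound 3 to compound 4 (0.57 log units; beyond the scatter).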

Compound 4, inhibition constant: 6.7 nM
Beside the measured number, compound 4's estimate is 2.2-fold (0.35 log units) below it; the measured number falls inside the stated range.
By their numbers in this assay, from the lowest: compounds 3 and 1 (each within the scatter of the next); then compounds 2 and 4 (each within the scatter of the next).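

Replacing 4-phenylpiperazin-1-yl with butylsulfanyl on this aromatic carbon gives an 8.4-fold higher number from compound 3 to compound 4 (0.92 log units; beyond the scatter), so this position on a ring of carbon only responds clearly to the change of group. Even so, compound 4 gives 6.7 nM in this assay, which shows that a chain with no ring at this place still leaves a working inhibitor. No measurement shown here accounts for the rise. The compounds shown leave open whether the rise follows from losing the rings or from bringing in the sulfur. A butoxy chain or a butylamino group at this position would separate the sulfur from the chain, while a piperidine ring would test a single ring in place of the two.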